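The compounds below may be only part of what the source reports. "The series", "measured", "known", "first", "only" and "open" are said of these compounds alone.

Measured in a physicochemical assay for lipophilicity, read by HPLC; a lower number here means a more polar compound, a higher number a more lipophilic compound:
compound 1 `CCCn1cc(C(=O)NCc2ccccc2)c(=O)c2cc(F)c(N3CCC(C(N)=O)CC3)cc21`: 2.4
compound 2 `CCCCn1cc(C(=O)NCc2ccccc2)c(=O)c2cc(F)c(N(C)C)cc21`: 2.4

Compound 1 stands level with compound 2 in this assay, within the usual scatter. These two compounds differ in more than one place, so no single change can be read from them. Compound 3 `NC(=O)C1CCN(c2cc3c(cc2F)c(=O)c(C(=O)NCc2ccccc2)cn3C2CC2)CC1` keeps the core of compound 1 but carries cyclopropyl in place of propyl on an aromatic nitrogen. For the measured compounds named here, no measured pair shows this swap, so the expectation rests on judgement alone: a small move towards the polar end of this assay, close to the edge of the scatter. The estimated change is a number 0.30 log units lower from compound 1 to compound 3 (within the scatter). For compound 3 the expected value is 2.1, with an estimated range from 1.8 to 2.4.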

Compound 3, partition coefficient: 2.4
Beside the measured number, compound 3's estimate is 0.30 log units below it, and the stated range covers the measured number.
By their numbers in this assay, from the lowest: compounds 1, 2 and 3 (each within the scatter of the next).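

In this assay, cyclopropyl in place of propyl on an aromatic nitrogen gives no change at the digits printed from compound 1 to compound 3 (within the scatter), a single-change reading at this position that compounds 1 and 2 could not provide. On the core of compound 1, a three-membered ring can therefore stand in for the open propyl chain with the same printed number. Nothing available explains this result.

As far as these compounds go, whether a longer chain such as pentyl, or a chain carrying an amine, on this nitrogen would give the same reading remains open. So does whether this swap would read the same on another core.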